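This account rests on a few compounds, and the source may have more. Where it says the series, first, only, none or still open, it means among the compounds named here.

Measured so far in a physicochemical assay for lipophilicity, read by HPLC, at pH 7.5; on this read-out higher numbers stand for higher lipophilicity and lower numbers for lower lipophilicity
- compound 1 `CC[C@@H](Nc1c(C#N)c(-c2ccc(-c3cccc(C)c3F)cc2)nc2cnccc12)C(N)=O` gives 3
- compound 2 `CC[C@H](Nc1c(C#N)c(-c2ccc(Br)cc2)nc2cnccc12)C(N)=O` gives 2.3
- compound 3 `CCOc1ccccc1-c1ccc(-c2nc3cnccc3c(N[C@H](CC)C(=O)O)c2C#N)cc1` gives 2.1

Among these three, compound 2 at 2.3 sits within the scatter of compound 3 (2.1). Compound 1 (3) stands higher than compound 2, and that gap lies beyond the scatter. Going by the values given here, the three differ from one another in more than one place, so these numbers give no measured step for any single change.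

The next compound to be read in this assay is compound 4 `CC(Nc1c(C#N)c(-c2ccc(Br)cc2)nc2cnccc12)C(N)=O`. Its difference from compound 2 is confined to one group, and it reads 1-carbamoylethyl in place of 1-carbamoylpropyl on a nitrogen on an aromatic ring as the whole of the change. The entering 1-carbamoylethyl carries no defined stereocentre, while the leaving 1-carbamoylpropyl carries one.

Among the compounds with values here, with no measured pair to lean on, the expectation rests on the structural change alone and starts from compound 2 at 2.3 in this assay as the reference. The expected move is a number 0.40 log units lower from compound 2 to compound 4 (beyond the scatter) and it is estimated as a small fall just beyond the scatter. The estimated value for compound 4 is 1.9 and the expected range runs from 1.6 to 2.2 for this measurement.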

Compound 4, distribution coefficient: 2.1
Beside the measured number, compound 4's estimate is 0.20 log units below it; low and high end bracket the measured number.
By their numbers in this assay, from the lowest: compounds 3, 4 and 2 (each within the scatter of the next); then compound 1.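

In this assay, going by these compounds alone, the change to 1-carbamoylethyl in place of 1-carbamoylpropyl on a nitrogen on an aromatic ring gives a number 0.20 log units lower from compound 2 to compound 4 (within the scatter), the first measured step at this position, since the earlier compounds differed from one another in more than one place. On this read-out, the step therefore does not separate the two compounds, with the bromo-substituted remainder of the structure held constant. The change also removes the defined stereocentre of the leaving group, so this single step joins a shorter chain and a lost stereocentre, and no available evidence explains the result or assigns any part of it to either feature.

The compounds shown leave open whether each enantiomer of the 1-carbamoylethyl compound would read like compound 4, and whether a longer chain such as 1-carbamoylbutyl would give a step beyond the scatter. They also leave open how this read-out would respond to an amine or a hydroxyl group in place of the carbamoyl group on the same chain.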